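This account rests on a few compounds, and the source may have more. Where it says the series, first, only, none or still open, it means among the compounds named here.

Three compounds share one core and differ only in the group on the phenyl ring that hangs from the piperazine nitrogen. Compound 1 `CCC(C(=O)N1CCN(c2cccc(F)c2)CC1)N1C(=O)CCC1=O` carries a 3-fluorophenyl there, compound 2 `CCC(C(=O)N1CCN(c2ccccc2F)CC1)N1C(=O)CCC1=O` a 2-fluorophenyl, and compound 3 `CCC(C(=O)N1CCN(c2ccccc2C(F)(F)F)CC1)N1C(=O)CCC1=O` a 2-(trifluoromethyl)phenyl. In a functional assay on the whole organism (strain Swiss) with Mus musculus as the target, in the maximal electroshock model, with a stated time of 0.5 h, at a dose of 300 mg/kg by the intraperitoneal route (on this read-out lower numbers stand for a weaker effect and higher numbers for a stronger effect at the one dose given), compound 1 gives 100% and compound 2 gives 100%, so the step of no change at the digits printed from compound 1 to compound 2 (within the scatter) shows no real difference; the two differ as 3-fluorophenyl in place of 2-fluorophenyl on an amine nitrogen in a ring. Compound 3 gives 25% in this assay, a fall described by a number 75 percentage points lower from compound 2 to compound 3 (beyond the scatter) for the change (trifluoromethyl in place of fluoro on an aromatic carbon).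

Compound 4 `CCC(C(=O)N1CCN(c2cccc(C(F)(F)F)c2)CC1)N1C(=O)CCC1=O` has not been measured. It differs from compound 1 as trifluoromethyl in place of fluoro on an aromatic carbon, and this is the same kind of change as that from compound 2 to compound 3, seen twice among these compounds. It is not the same, though: in compound 4 the new group sits meta to a large group, whereas in compound 3 it sits ortho to a large group.

For the measured compounds named here, only one measured example of this kind of change exists, and it is at a different place on the ring, so the estimate is uncertain. The expected step for compound 4, a number 40 percentage points lower from compound 1 to compound 4 (beyond the scatter), is estimated as smaller than the measured step of this kind. Compound 4 is expected to give about 60% in this assay, between 25% and 100%.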

Compound 4, a percentage reported as activity, at one dose (the size of the read-out at that dose, not a potency): 50%
Compound 4: middle estimate off by 10 percentage points, on the high side; the measured number falls inside the stated range.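

In this assay, putting trifluoromethyl in place of fluoro on the aromatic carbon gives a number 50 percentage points lower from compound 1 to compound 4 (beyond the scatter), so the second example of this change points the same way as the first. The direction of the change carries from one core to the other in this series, but its size does not: the same change on two cores in this assay, a number 75 percentage points lower (beyond the scatter) from compound 2 to compound 3 and a number 50 percentage points lower (beyond the scatter) from compound 1 to compound 4, 25 percentage points apart, beyond the scatter of two such steps. For the compounds shown here, this rests on only two pairs, and although the new group in compound 4 sits meta to a large group, the result does not show that its place on the ring sets the size of the step, nor does it give any cause for the gap; and since the read-out comes from one dose, neither step is a change in potency.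

The compounds shown leave open how the read-out would respond to other groups on the same ring, such as chloro, methyl, methoxy or nitrile, and so whether the lower values belong to trifluoromethyl alone or would also appear with other groups in place of fluoro. They also leave open whether the same change would behave alike on a core with a longer chain in place of the ethyl group, or with an amine on the ring.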